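Cyclopentyl on the carbonyl of compound 1

This account rests on a few compounds, and the source may have more. Where it says the series, first, only, none or still open, it means among the compounds named here.

Compound 1 `Cc1nc(S(C)(=O)=O)ccc1Oc1ncnc(OC2CCN(C(=O)O[C@@H](C)CF)CC2)c1F` is the weakest point among the three measured compounds in a functional assay on isolated protein for inhibition of Glucose-dependent insulinotropic receptor (Rattus norvegicus), read by HTRF and cAMP accumulation (a higher number here means that more compound is needed for the effect, a lower number that less compound is needed), where compound 1 gives 1680 nM. Compound 2 `Cc1nc(S(C)(=O)=O)ccc1Oc1ncnc(OC2CCN(C(=O)OC3(C(F)(F)F)CCC3)CC2)c1F` gives 63.3 nM, and compound 3 `Cc1nc(S(C)(=O)=O)ccc1Oc1ncnc(OC2CCN(C(=O)C(F)(F)F)CC2)c1F` gives 880 nM. The two measured steps from compound 1 differ sharply in size: a 27-fold lower number from compound 1 to compound 2 (1.42 log units; beyond the scatter), whereas a 1.9-fold lower number from compound 1 to compound 3 (0.28 log units; within the scatter). Between the other two, a 14-fold higher number from compound 2 to compound 3 (1.14 log units; beyond the scatter).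

Compound 4 `Cc1nc(S(C)(=O)=O)ccc1Oc1ncnc(OC2CCN(C(=O)C3CCCC3)CC2)c1F` has not been measured. Relative to compound 1 the change is a group of 5 heavy atoms (5 carbon; one five-membered non-aromatic ring of carbon only) in place of a group of 5 heavy atoms (3 carbon, 1 oxygen, 1 fluorine; no ring), on a carbonyl carbon. Both measured steps from compound 1 bear on it. The step to compound 2 shows that a ring-containing group on this side of the carbonyl can lower the number a great deal, but there the ring stayed on an oxygen next to the carbonyl. The step to compound 3 shows that removing the oxygen and placing a small group directly on the carbonyl leaves the number within the scatter. The cyclopentyl case lies between these: a ring enters, the oxygen leaves. A lower number is therefore expected, though well short of the step to compound 2, and a 4.2-fold lower number from compound 1 to compound 4 (0.62 log units; beyond the scatter) is the expected size. For compound 4 the estimate in this assay is 400 nM, with a range from 120 nM to 1300 nM.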

Compound 4, half-maximal effective concentration: 407 nM
Compound 4: the middle estimate sits 1.0-fold (0.01 log units) below what was measured; measured number inside the range.
By their numbers in this assay, from the lowest: compound 2; then compound 4; then compounds 3 and 1 (each within the scatter of the next).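

In this assay cyclopentyl on the carbonyl carbon gives a 4.1-fold lower number from compound 1 to compound 4 (0.62 log units; beyond the scatter) although the group it replaces carried an oxygen, so in this series a ring can move the number beyond the scatter without that oxygen. The identity of a group placed directly on the carbonyl carbon also matters: trifluoromethyl stayed within the scatter of compound 1, whereas cyclopentyl in its place gives a 2.2-fold lower number from compound 3 to compound 4 (0.33 log units; beyond the scatter) and separates the two groups. A ring on its own does not reach the lowest number in the set, since a 6.4-fold higher number from compound 2 to compound 4 (0.81 log units; beyond the scatter) still stands against cyclopentyl and in favour of the 1-(trifluoromethyl)cyclobutyl group on oxygen, which differs from cyclopentyl in ring size, oxygen and fluorine all at once.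

With those three differences bundled into a single step, the share of each stays unresolved, as does whether cyclohexyl, phenyl or a longer chain on the carbonyl carbon would fall above or below cyclopentyl. No measurement at hand gives a reason for any of these steps.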